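Microsomal stability of the shared core: benzyloxy to dimethylaminoethyl

The source may report more compounds than this note shows. Statements on the series, on what has been measured and on what is new or still open speak of the compounds shown alone.

Measured compounds and values in an in vitro ADME assay on microsomes from liver (Mus musculus) for metabolic stability, read by LC-MS; a lower number here means that the compound disappears faster, a higher number that the compound lasts longer:
- compound 1 `CON/C(=N\C1=NC(=O)C(=O)N1C(C)C)Nc1ccc(Cl)c(Cl)c1`: > 1 h
- compound 2 `CCON/C(=N\C1=NC(=O)C(=O)N1C(C)C)Nc1ccc(Cl)c(Cl)c1`: > 1 h
- compound 3 `CC(C)N1C(=O)C(=O)N=C1/N=C(\NOCc1ccccc1)Nc1ccc(Cl)c(Cl)c1`: > 1 h

Each of these values is a limit of this assay and not a number. Compound 1 sits at > 1 h, a limit. Compound 2 likewise sits at a limit, > 1 h. Compound 3 also gives only a limit, > 1 h. Accordingly (the limit of > 1 h in this assay, at which 3 of the 3 values shown sit), and compound 3 stands with the others at that limit, with no number to rank it by.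

The three measured steps are all unreadable: a step that the two limits leave unreadable from compound 1 to compound 2, a step that the two limits leave unreadable from compound 1 to compound 3 and a step that the two limits leave unreadable from compound 2 to compound 3. None of them gives a size.

Compound 4 `CC(C)N1C(=O)C(=O)N=C1/N=C(\NCCN(C)C)Nc1ccc(Cl)c(Cl)c1` differs from compound 3 by 2-(dimethylamino)ethyl in place of benzyloxy on an amine nitrogen. For the measured compounds named here, no measured step touches this part of the structure, and the steps that do exist have no readable size, so they give no direction and no magnitude for this assay. With the three measured compounds all at the limit, the change from compound 3 to compound 4 is expected to be a step that the limit leaves unreadable from compound 3 to compound 4, within scatter. Compound 4 is therefore estimated at 1.2 h in this assay, between 0.5 h and 3 h, with a fair chance that only a limit is again reported.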

Compound 4, half-life: > 1 h
Compound 4 gave a limit, no number; the forecaster's own chance of this, stated with the estimate: 55%; the middle value lies beyond the limit too.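

In this assay compound 4 gives > 1 h, a limit and not a number. The steps from compound 1, compound 2 and compound 3 to compound 4 cannot be read: the limit of > 1 h in this assay, at which 4 of the 4 values shown sit.

As far as these compounds go, how the four compounds rank in this assay, and whether the group on the amine nitrogen matters, stays open.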